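Ester Swap on a Shared Core: Propyl to Phenyl

The source may hold more compounds than are shown below. What is called first, only, known or untested is meant among the compounds shown, and "the series" means these compounds.

Compound 1 `O=CCc1c(-c2ccccc2Cl)c2cc(Cl)ccc2[nH]c1=O` gives 120000 nM in an ADME assay on HepG2 2.2.15 cells (Homo sapiens) for cytotoxicity; a higher number here means that more compound is tolerated, a lower number that less compound is tolerated.
Compound 2 `CCCC(=O)OCCc1c(-c2ccccc2Cl)c2cc(Cl)ccc2[nH]c1=O` gives 52000 nM in this assay.
Compound 3 `O=C(OCCc1c(-c2ccccc2Cl)c2cc(Cl)ccc2[nH]c1=O)C1CCCC1` gives 46000 nM in this assay.

Among these three numbers, compound 2 has the second highest. Its nearest neighbour is compound 3, and the two lie within the scatter of each other, as a 1.1-fold lower number from compound 2 to compound 3 (0.05 log units; within the scatter) shows. Compound 1 sits further away, with a 2.3-fold lower number from compound 1 to compound 2 (0.36 log units; beyond the scatter) marking a modest drop in tolerated concentration when the formyl group is replaced by an ester-bearing chain; a 2.6-fold lower number from compound 1 to compound 3 (0.42 log units; beyond the scatter) tells the same story for the other ester.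

Compound 4 `O=C(OCCc1c(-c2ccccc2Cl)c2cc(Cl)ccc2[nH]c1=O)c1ccccc1` differs from compound 2 in one place: phenyl in place of propyl on a carbonyl carbon. For the measured compounds named here, the step that bears most directly on this change is the one from compound 2 to compound 3, where another group replaced propyl on the same carbonyl carbon and the number stayed within the scatter. On that basis no step beyond the scatter is expected in this assay for compound 4, so a 1.2-fold lower number from compound 2 to compound 4 (0.06 log units; within the scatter) is the expectation. Compound 4 is therefore estimated at 45000 nM, with a range from 22000 nM to 90000 nM.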

Compound 4, half-maximal cytotoxic concentration: 43000 nM
Estimate against measurement, compound 4: 1.0-fold (0.02 log units) above, within the range that was stated.
By their numbers in this assay, from the lowest: compounds 4, 3 and 2 (each within the scatter of the next); then compound 1.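

In this assay, swapping to an aromatic ring on the carbonyl carbon gives a 1.2-fold lower number from compound 2 to compound 4 (0.08 log units; within the scatter) and a 1.1-fold lower number from compound 3 to compound 4 (0.03 log units; within the scatter), so propyl, cyclopentyl and phenyl cannot be told apart at this place. All three esters still differ from the formyl compound, and the aromatic ester does so with a 2.8-fold lower number from compound 1 to compound 4 (0.45 log units; beyond the scatter) and the same modest size of step. Nothing available explains why the number hardly responds to the group on the carbonyl carbon.

From the compounds shown here alone, it remains open whether an amine or a carboxylic acid on the carbonyl carbon, or a longer chain in place of propyl, would leave the number within the scatter. Going by these compounds, it is also open whether a simple hydroxyl group in place of formyl would produce a similar step.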